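Working notes: (trifluoromethyl)sulfanyl in place of methoxy

A few compounds are considered here, and "the series" means these few. Any claim that something is new, unique, unknown or untested is made for them only; others in the source may bear on it.

Measured so far:
compound 1 `O=C(Nc1ccccc1)C(Cl)Cl`, whose entry in a functional assay on Bel-7402 cells (Homo sapiens) for antiproliferative activity, read by MTT assay, with a stated time of 72 h (a lower number here means a stronger inhibitor, a higher number a weaker inhibitor), reads "not determined" (no result reported)
compound 2 `COc1cccc(NC(=O)C(Cl)Cl)c1`, which gives 54800 nM in this assay

For the measured compounds named here, compound 2 holds the only number in this assay; compound 1 has none there, so no step between measured compounds is available. Compound 3 `O=C(Nc1cccc(SC(F)(F)F)c1)C(Cl)Cl` differs from compound 2 by (trifluoromethyl)sulfanyl in place of methoxy on an aromatic carbon. Going by the values given here, with no measured step to lean on, the step from compound 2 to compound 3 is expected to be modest and toward a lower value, possibly within the scatter, a 1.8-fold lower number from compound 2 to compound 3 (0.26 log units; within the scatter). Compound 3 is therefore estimated at 30000 nM, in a range from 8000 nM to 120000 nM.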

Compound 3, half-maximal inhibitory concentration: 6540 nM
Estimate against measurement, compound 3: 4.6-fold (0.66 log units) above; the measured number lies below the stated range.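

In this assay, for the compounds shown here, the aromatic carbon meta to a group of 6 heavy atoms proves sensitive to its substituent: (trifluoromethyl)sulfanyl in place of methoxy gives an 8.4-fold lower number from compound 2 to compound 3 (0.92 log units; beyond the scatter), the first step that can be read. This rests on a single pair, as compound 1 has no value to set against either compound. No measurement shown bears on the cause of this step.

As far as these compounds go, whether an amine, a carboxylic acid or a longer alkyl chain at this carbon would move the number in the same direction remains open. So does the outcome of the same exchange on other aromatic carbons.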